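Swapping the amide ring for a cyclopropyl group

The compounds below may be only part of what the source reports. "The series", "measured", "known", "first", "only" and "open" are said of these compounds alone.

Compound 3 `O=C(/C=C/c1ccncc1-c1ccc2ccccc2c1)N1CCOCC1` is the reference point. In an assay on a protein complex for inhibition of CDK8/Cyclin C (Homo sapiens), with a stated time of 1 h (a lower number here means a stronger inhibitor, a higher number a weaker inhibitor), compound 3 gives 60.3 nM, the lowest of the two numbers available. For the measured compounds named here, its nearest neighbour, compound 1 `O=C(O)CCNC(=O)/C=C/c1ccncc1-c1ccc2ccccc2c1`, gives 870 nM in this assay, and the single measured step, a 14-fold lower number from compound 1 to compound 3 (1.16 log units; beyond the scatter), exchanges a (2-carboxyethyl)amino group for a morpholin-4-yl group on the carbonyl carbon. Compound 2 `CC(C)[C@@H](NC(=O)/C=C/c1ccncc1-c1ccc2ccccc2c1)C(=O)O` carries a different amino acid on that carbonyl, but in this assay compound 2 gives "not determined" (no result reported), so no number is available for it.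

Compound 4 `O=C(/C=C/c1ccncc1-c1ccc2ccccc2c1)NC1CC1` differs from compound 3 in one place: cyclopropylamino in place of morpholin-4-yl on a carbonyl carbon. Going by the values given here, no measured step covers this particular exchange. Among the compounds with values here, the one step available, from (2-carboxyethyl)amino to morpholin-4-yl, was large, but it does not show how a cyclopropylamino group compares with a morpholin-4-yl group. One hydrogen-bond donor enters and one hydrogen-bond acceptor leaves, so a shift of modest size in either direction seems as likely as none beyond the scatter. Compound 4 is therefore expected to land near compound 3, with the step of a 1.7-fold higher number from compound 3 to compound 4 (0.22 log units; within the scatter) taken as the best guess. The estimate for compound 4 in this assay is 100 nM, ranging from 30 nM to 400 nM.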

Compound 4, half-maximal inhibitory concentration: 40.1 nM
Estimate against measurement, compound 4: 2.5-fold (0.40 log units) above; low and high end bracket the measured number.
By their numbers in this assay, from the lowest: compounds 4 and 3 (each within the scatter of the next); then compound 1.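

On the carbonyl carbon, the morpholin-4-yl ring can give way to the smaller cyclopropylamino group in this assay with no change that stands out from the scatter: the step is a 1.5-fold lower number from compound 3 to compound 4 (0.18 log units; within the scatter). The amide hydrogen therefore does no visible harm here, and the ring oxygen of morpholin-4-yl is not needed to keep the number low. Compound 1 and compound 4 both keep that hydrogen and differ only in the other group on the nitrogen, and a 22-fold lower number from compound 1 to compound 4 (1.34 log units; beyond the scatter) places the weakness of compound 1 with its 2-carboxyethyl group rather than with the amide hydrogen, something the morpholin-4-yl step alone could not separate, though no measurement shown explains why either group behaves as it does.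

Still open, going by these compounds, is whether the carboxylic acid itself or the chain that carries it accounts for the higher number, which a plain propyl group on the same nitrogen would help to settle. Also open, on these data alone, is how far this position tolerates other groups, such as a piperidin-1-yl ring, which lacks the morpholine oxygen, or a longer chain ending in an amine.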